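This account rests on a few compounds, and the source may have more. Where it says the series, first, only, none or still open, it means among the compounds named here.

Compound 1 `Cc1ccc(C2CC(=O)c3ccc(C)cc3O2)cc1` is the reference point of this small series. Among the compounds with values here, in an in vitro assay on BTI-TN-5B1-4 cells for inhibition of Amine oxidase [flavin-containing] B (Homo sapiens) (a higher number here means a weaker inhibitor, a lower number a stronger inhibitor), compound 1 gives 500 nM, the lowest of the three numbers measured so far. Compound 2 `Cc1ccc([C@H]2CC(=O)c3ccc(C)cc3O2)cc1` has the same atoms and bonds and gives 530 nM in this assay; the step of a 1.1-fold higher number from compound 1 to compound 2 (0.03 log units; within the scatter) is within the scatter, the two differing only in the fact that one of compounds 1 and 2 is drawn with a defined configuration and the other without, at the place where they differ. Compound 3 `Cc1ccc(C2CC(=O)c3ccccc3O2)cc1` gives 2070 nM, and the step of a 4.1-fold higher number from compound 1 to compound 3 (0.62 log units; beyond the scatter) shows that removing one methyl group costs a modest amount of potency.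

Compound 4 `Cc1ccc2c(c1)OC(c1ccc(F)cc1)CC2=O` has not yet been measured. It differs from compound 1 by fluoro in place of methyl on an aromatic carbon. Within the data shown here, no measured step matches this change exactly. The step from compound 1 to compound 2 concerns only a drawn configuration and says nothing about it. The step from compound 1 to compound 3 removes a methyl, though not the one replaced here, and it weakened binding modestly. Taking that as the closest guide, a modest increase in the number is expected for compound 4, with the step of a 2.4-fold higher number from compound 1 to compound 4 (0.38 log units; beyond the scatter) expected. Compound 4 is therefore estimated at 1200 nM in this assay, within a range from 400 nM to 3500 nM.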

Compound 4, half-maximal inhibitory concentration: 130 nM
Beside the measured number, compound 4's estimate is 9.2-fold (0.97 log units) above it; measured number outside the range, below it.
By their numbers in this assay, from the lowest: compound 4; then compounds 1 and 2 (each within the scatter of the next); then compound 3.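

Swapping the methyl on the aromatic carbon para to a large group for a fluoro gives a 3.8-fold lower number from compound 1 to compound 4 (0.59 log units; beyond the scatter) in this assay, so this position can hold something other than methyl without losing potency, and the swap in fact strengthens inhibition. Within the data shown here, the earlier compounds gave no such sign: removing a different methyl raised the number, and a drawn configuration made no difference beyond the scatter, so this is the first single change that lowers the number beyond the scatter, and it shows that the two methyl positions on the core need not be read alike. The information available on these compounds offers no explanation for this gain, so the size of the step stands here as an observation only.

The compounds shown leave open how a plain hydrogen at this same position would compare, and whether a chloro, a methoxy, an amine or a carboxylic acid there would lower the number further or raise it. They also leave open whether the gain from fluoro would persist with the other methyl replaced by hydrogen.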